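The compounds below may be only part of what the source reports. "The series", "measured", "known", "first", "only" and "open" are said of these compounds alone.

Three analogues sharing one core were measured in an assay on HEK293 cells for positive allosteric modulation of metabotropic glutamate receptor 3 (Rattus norvegicus), read by thallium flux, with a stated time of 2.5 min; on this read-out lower numbers stand for smaller maximal responses and higher numbers for larger maximal responses. Compound 2 `Cc1c(OCCCCOc2ccc(C(=O)O)cc2F)ccc(C(=O)CC(C)C)c1O` gives 67.7% in this assay. Compound 1 `Cc1c(OCCCCOc2ccc(C(=O)O)cc2F)ccc(C(=O)CC2CCCC2)c1O` differs from compound 2 by cyclopentyl in place of isopropyl on a saturated chain carbon bound to a carbonyl carbon, and compound 1 gives 31.2%; the step of a number 36.5 percentage points lower from compound 2 to compound 1 (beyond the scatter). Compound 3 `Cc1ccc(C(=O)O)cc1OCCCCOc1ccc(C(=O)CC(C)C)c(O)c1C` differs from compound 2 by 5-carboxy-2-methylphenyl in place of 4-carboxy-2-fluorophenyl on an oxygen on a saturated carbon, and compound 3 gives 29.4%; the step of a number 38.3 percentage points lower from compound 2 to compound 3 (beyond the scatter). Compound 4 `Cc1ccc(C(=O)O)cc1OCCCCOc1ccc(C(=O)CC2CCCC2)c(O)c1C` is not yet measured; it differs from compound 3 by cyclopentyl in place of isopropyl on a saturated chain carbon bound to a carbonyl carbon, the same change as from compound 2 to compound 1, made on a core that differs as described by 5-carboxy-2-methylphenyl in place of 4-carboxy-2-fluorophenyl on an oxygen on a saturated carbon. Because the earlier step of a number 36.5 percentage points lower from compound 2 to compound 1 (beyond the scatter) was a large drop from a higher starting point, and compound 3 already stands at 29.4%, the author expects a smaller step, a number 9.4 percentage points lower from compound 3 to compound 4 (within the scatter), in this assay. The estimated value for compound 4 is therefore 20%, between 5% and 40%.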

Compound 4, largest response reached (reported as percent of maximum), in percent of the reference or control that the assay uses: 26.9%
Beside the measured number, compound 4's estimate is 6.9 percentage points below it; measured number inside the range.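

On the core of compound 3, cyclopentyl in place of isopropyl gives a number 2.5 percentage points lower from compound 3 to compound 4 (within the scatter) in this assay, so the large drop seen on the other core does not carry over: the same change on two cores in this assay, a number 36.5 percentage points lower (beyond the scatter) from compound 2 to compound 1 and a number 2.5 percentage points lower (within the scatter) from compound 3 to compound 4, 34 percentage points apart, beyond the scatter of two such steps. Exchanging 4-carboxy-2-fluorophenyl for 5-carboxy-2-methylphenyl likewise gives a number 4.3 percentage points lower from compound 1 to compound 4 (within the scatter) with cyclopentyl in place, against a large drop with isopropyl: the same change on two cores in this assay, a number 38.3 percentage points lower (beyond the scatter) from compound 2 to compound 3 and a number 4.3 percentage points lower (within the scatter) from compound 1 to compound 4, 34 percentage points apart, beyond the scatter of two such steps. The two changes therefore do not add up across these four compounds, but this does not show the reason, and a single pair of cores gives no rule for any other core.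

The compounds shown leave open how cyclohexyl in place of cyclopentyl, or a tetrazole in place of the carboxylic acid, would behave on either core.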